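This account rests on a few compounds, and the source may have more. Where it says the series, first, only, none or still open, it means among the compounds named here.

Measured compounds:
- compound 1, `N/C(=N\NC(=S)N1CCCCCC1)c1ccccn1`: 740 nM
- compound 2, `N/C(=N\NC(=S)N1CCOCC1)c1ccccn1`: 680 nM
- compound 3, `Cc1cccc(/C(N)=N/NC(=S)N2CCOCC2)n1`: 14000 nM

These three were tested in a functional assay on A-375 cells (Homo sapiens) for cytotoxicity, read by MTT assay, with a stated time of 72 h; on this read-out lower numbers stand for stronger inhibition and higher numbers for weaker inhibition. Compound 1 gives 740 nM and compound 2 gives 680 nM, two numbers that lie within the scatter of each other, so no order between them can be read. The difference between the core of compound 1 and the core of compound 2 is not broken down here.

Compound 3 differs from compound 2 by one change: methyl in place of hydrogen on an aromatic carbon. This change made a step of a 21-fold higher number from compound 2 to compound 3 (1.31 log units; beyond the scatter), a large loss of potency.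

Compound 4, `Cc1ccnc(/C(N)=N/NC(=S)N2CCCCCC2)c1`, is not yet measured. It differs from compound 1 by methyl in place of hydrogen on an aromatic carbon. For the measured compounds named here, this is the same kind of change as the one from compound 2 to compound 3, but not the same: in compound 3 the methyl sits next to the ring nitrogen, while in compound 4 it sits opposite the ring nitrogen, in both cases meta to a large group.

Going by the values given here, because the only measured example of this kind of change is a 21-fold higher number from compound 2 to compound 3 (1.31 log units; beyond the scatter), some loss of potency is expected for compound 4 as well. Since the place of the methyl is not the same, the step is expected to be smaller and more uncertain, estimated as a 2.4-fold higher number from compound 1 to compound 4 (0.39 log units; beyond the scatter). Compound 4 is therefore expected to give about 1800 nM in this assay, most likely between 500 nM and 7000 nM.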

Compound 4, half-maximal inhibitory concentration: 800 nM
Compound 4: middle estimate off by 2.3-fold (0.35 log units), on the high side; low and high end bracket the measured number.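

In this assay, methyl in place of hydrogen on an aromatic carbon gave a 1.1-fold higher number from compound 1 to compound 4 (0.03 log units; within the scatter), so on the core of compound 1 this change has no effect that can be told from the scatter. The same kind of change therefore does not carry over as one fixed step from one core to another in this series: the same change on two cores in this assay, a 21-fold higher number (1.31 log units; beyond the scatter) from compound 2 to compound 3 and a 1.1-fold higher number (0.03 log units; within the scatter) from compound 1 to compound 4, 19-fold (1.28 log units) apart, beyond the scatter of two such steps What this does not show is the reason, since the two steps differ both in the core and in the place of the methyl, which sits opposite the ring nitrogen in compound 4 but not in compound 3, and two steps alone cannot separate these.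

Still open, going by these compounds, is what a methyl opposite the ring nitrogen would do on the core of compound 2, and what a methyl at its place in compound 3 would do on the core of compound 1; these two pairs would show whether the core or the place matters. Also open, on these data alone, is whether a different group opposite the ring nitrogen, such as an ethyl, a methoxy or an amine, would leave the number as little changed as methyl does.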